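The source may report more compounds than this note shows. Statements on the series, on what has been measured and on what is new or still open speak of the compounds shown alone.

Measured compounds:

Compound 1, `O=C(O)Cc1sc(CS(=O)(=O)c2ccc(Cl)cc2)nc1-c1ccc(Cl)cc1`, gives 730 nM.
Compound 2, `O=C(O)Cc1sc(C(c2ccccc2)c2ccc(F)cc2)nc1-c1ccc(Cl)cc1`, gives 36 nM.
Compound 3, `O=C(O)Cc1sc(C(c2ccc(F)cc2)c2ccc(F)cc2)nc1-c1cccc(F)c1`, gives 18 nM.

All three were tested in an in vitro functional assay on HEK285-7 cells for antagonist activity at prostaglandin D2 receptor 2 (Homo sapiens), read by BRET and beta-arrestin recruitment; on this read-out lower numbers stand for stronger inhibition and higher numbers for weaker inhibition. Compound 3 has the lowest number of the three, but its gap to compound 2 lies within the scatter, so the two cannot be told apart on these figures; only its gap to compound 1 is beyond the scatter.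

Compound 4, `O=C(O)Cc1sc(C(c2ccc(F)cc2)c2ccc(F)cc2)nc1-c1cc(F)nc(F)c1`, has not yet been measured. It differs from compound 3 in one place: 2,6-difluoropyridin-4-yl in place of 3-fluorophenyl on an aromatic carbon. The rest of the molecule, including the shared core and the group carrying two fluorophenyl rings, is kept.

Among the measured compounds shown here, no pair among the measured compounds shows this kind of exchange, so the data give no direct guide to its effect. For the measured compounds named here, with no measured step to lean on, the expectation is for a small change in this assay, if any, most likely a slight rise in the number, with the step from compound 3 to compound 4 estimated as a 2.2-fold higher number from compound 3 to compound 4 (0.35 log units; beyond the scatter). On that basis compound 4 is expected to give about 40 nM, with a range from 10 nM to 160 nM.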

Compound 4, half-maximal inhibitory concentration: 110 nM
The estimate for compound 4 lay 2.8-fold (0.44 log units) below the measured number, and the stated range covers the measured number.
By their numbers in this assay, from the lowest: compounds 3 and 2 (each within the scatter of the next); then compound 4; then compound 1.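

Among the compounds shown here, this is the only exchange in the set that changes a single place, so it gives the first direct reading of the aromatic carbon on the five-membered ring, next to the ring nitrogen and next to the ring atom that bears the carboxymethyl group. In this assay, 2,6-difluoropyridin-4-yl in place of 3-fluorophenyl gives a 6.1-fold higher number from compound 3 to compound 4 (0.79 log units; beyond the scatter), a modest step showing that inhibition at this position depends on which aromatic ring is attached, yet survives the exchange of a carbon-only ring for one with a ring nitrogen and an extra fluorine. Nothing measured here accounts for the rise in the number.

The exchange adds the ring nitrogen and the second fluorine together, so the compounds shown leave open which of the two goes with the weaker inhibition. A difluorophenyl ring or a pyridine ring without fluorine could separate them, and a cyclohexyl group would test whether an aromatic ring is needed at this position at all.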